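A few compounds are considered here, and "the series" means these few. Any claim that something is new, unique, unknown or untested is made for them only; others in the source may bear on it.

Of the compounds shown here, three built on a shared core have been measured in a functional assay on U-937 cells (Homo sapiens) for cytotoxicity, read by MTT assay, with a stated time of 24 h; on this read-out higher numbers stand for weaker inhibition and lower numbers for stronger inhibition. Compound 2 `COc1c(Br)cc(Br)cc1Oc1ccc(Br)cc1Br` gives 34.5 ug/mL. Compound 3 `C#CCOc1c(Br)cc(Br)cc1Oc1ccc(Br)cc1Br` gives 29.5 ug/mL. Compound 1 `Brc1ccc(Oc2cc(Br)cc(Br)c2OCCCCCN2CCN(C/C=C/c3ccccc3)CC2)c(Br)c1`, which carries a much longer chain at the same place, gives 32.7 ug/mL. On these numbers compound 3 stands together with the other two: its value and those of compound 1 and compound 2 lie within the usual scatter of one another, so none of the three can be set apart.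

Compound 4 `BrCCCCCOc1c(Br)cc(Br)cc1Oc1ccc(Br)cc1Br` has not yet been measured. It differs from compound 3 in one place: 4-bromobutyl in place of ethynyl on a saturated chain carbon bound to an oxygen on an aromatic ring. For the measured compounds named here, the only measured step that touches this place is a 1.2-fold lower number from compound 2 to compound 3 (0.07 log units; within the scatter), which moved nothing beyond the scatter. Compound 1, with its own long chain at this place, likewise gives a number close to that of compound 3. Going by the values given here, nothing among the measured compounds points to a shift in this assay when the chain at this place is lengthened. Compound 4 is therefore expected to show no step beyond the scatter, a 1.0-fold higher number from compound 3 to compound 4 (0.01 log units; within the scatter), and its estimated value is 30 ug/mL, with a range from 15 ug/mL to 60 ug/mL.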

Compound 4, half-maximal inhibitory concentration: 29.5 ug/mL
Estimate against measurement, compound 4: 1.0-fold (0.01 log units) above; the measured number falls inside the stated range.
By their numbers in this assay, from the lowest: compounds 3, 4, 1 and 2 (each within the scatter of the next).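

In this assay, the place on a saturated chain carbon bound to an oxygen on an aromatic ring has now taken a bromine-bearing chain: 4-bromobutyl in place of ethynyl gives no change at the digits printed from compound 3 to compound 4 (within the scatter) and 4-bromobutyl in place of hydrogen gives a 1.2-fold lower number from compound 2 to compound 4 (0.07 log units; within the scatter) in this series. The earlier compounds had shown only the step from hydrogen to ethynyl at this place, so the flat result now extends to a chain with no triple bond, which enters with more heavy atoms and with bromine, and hydrogen, ethynyl and 4-bromobutyl cannot be told apart here. Nothing available explains why these changes leave the number within the scatter.

As far as these compounds go, it remains open whether an amine or a carboxylic acid at the far end of a chain of this kind, or a chain longer than 5-bromopentyl, would carry the number beyond the scatter at this place. From the compounds shown here alone, it is also open whether the same flat result would hold if chlorine or hydrogen replaced the bromine atoms on the shared core.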